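A Methyl Added to Compound 2

This account rests on a few compounds, and the source may have more. Where it says the series, first, only, none or still open, it means among the compounds named here.

In a functional assay on HCT-116 cells (Homo sapiens) for cytotoxicity, read by MTT assay, with a stated time of 72 h (a lower number here means a stronger inhibitor, a higher number a weaker inhibitor), compound 2 (`O=S(=O)(c1ccccc1)c1nc2ccccc2nc1N1CCC(O)CC1`) gives 1870 nM and compound 1 (`Cc1ccc(S(=O)(=O)c2nc3ccccc3nc2N2CCCC(O)C2)cc1`), which also bears 4-methylphenyl, gives 3270 nM there. These two values lie within the usual scatter of each other, so they cannot be ranked. Compound 3 (`Cc1ccc(S(=O)(=O)c2nc3ccccc3nc2N2CCC(O)CC2)cc1`), not yet measured, departs from compound 2 by one change (methyl in place of hydrogen on an aromatic carbon), with methyl in place of hydrogen on an aromatic carbon. Going by the values given here, no measured step isolates this change, and no shift beyond the scatter is expected in this assay here. The expected 1.2-fold higher number from compound 2 to compound 3 (0.09 log units; within the scatter) stays within the scatter. For compound 3 the estimated value is 2300 nM within an expected range of 1000 nM to 5000 nM in this assay.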

Compound 3, half-maximal inhibitory concentration: 5440 nM
The estimate for compound 3 lay 2.4-fold (0.37 log units) below the measured number; measured number outside the range, above it.
By their numbers in this assay, from the lowest: compounds 2, 1 and 3 (each within the scatter of the next, the first and the last beyond it).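

In this assay, methyl in place of hydrogen on an aromatic carbon, para to a large group, gives a 2.9-fold higher number from compound 2 to compound 3 (0.46 log units; beyond the scatter) and so shows that this position responds to the change, which the earlier pair could not show. The other new comparison, 4-hydroxypiperidin-1-yl in place of 3-hydroxypiperidin-1-yl, gives a 1.7-fold higher number from compound 1 to compound 3 (0.22 log units; within the scatter) and so does not separate those two compounds. Nothing measured here accounts for the methyl step.

The compounds shown leave open whether methyl acts alike with 3-hydroxypiperidin-1-yl in place. They also leave open how a methoxy group or a chlorine atom at this position would compare with methyl.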